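The source may hold more compounds than are shown below. What is called first, only, known or untested is meant among the compounds shown, and "the series" means these compounds.

Compound 1 `CCOC(=O)c1cc(CCl)nn1C1O[C@@H](COC(C)=O)[C@H](OC(C)=O)[C@@H](OC(C)=O)[C@@H]1OC(C)=O` and compound 2 `CCOC(=O)c1cc(CI)nn1C1O[C@@H](COC(C)=O)[C@H](OC(C)=O)[C@@H](OC(C)=O)[C@@H]1OC(C)=O` share one core. In a functional assay on HeLa cells (Homo sapiens) (on this read-out higher numbers stand for an effect only at larger amounts of compound and lower numbers for an effect already at smaller amounts), compound 1 gives 40 ug/mL, while compound 2 gives 2.5 ug/mL; the change iodo in place of chloro on a saturated chain carbon bound to an aromatic carbon thus brings a 16-fold lower number from compound 1 to compound 2 (1.20 log units; beyond the scatter). Compound 3 `CC(=O)OC[C@H]1O[C@@H](n2nc(C(N)=O)cc2CCl)[C@H](OC(C)=O)[C@@H]1OC(C)=O` has a different core, and the difference between the two cores is not broken down here; in this assay compound 3 gives 12 ug/mL, between the other two. Compound 4 `CC(=O)OC[C@H]1O[C@@H](n2nc(C(N)=O)cc2CI)[C@H](OC(C)=O)[C@@H]1OC(C)=O` is not yet measured and differs from compound 3 by iodo in place of chloro on a saturated chain carbon bound to an aromatic carbon, the same change as between compound 1 and compound 2, at the same place. Among the compounds with values here, because compound 2 gives 2.5 ug/mL after that change, a step of similar size is expected, a 15-fold lower number from compound 3 to compound 4 (1.18 log units; beyond the scatter), though only one earlier instance supports it. Compound 4 is therefore estimated at 0.8 ug/mL, likely between 0.3 ug/mL and 3 ug/mL.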

Compound 4, concentration for half-maximal effect: 2 ug/mL
Beside the measured number, compound 4's estimate is 2.5-fold (0.40 log units) below it; the range from low to high includes it.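

In this assay the change from chloromethyl to iodomethyl again gives a lower number, a 6.0-fold lower number from compound 3 to compound 4 (0.78 log units; beyond the scatter), so the direction of the step holds on both cores. Its size does not carry over unchanged, as the two steps differ by more than the scatter: the same change on two cores in this assay, a 16-fold lower number (1.20 log units; beyond the scatter) from compound 1 to compound 2 and a 6.0-fold lower number (0.78 log units; beyond the scatter) from compound 3 to compound 4, 2.7-fold (0.43 log units) apart, beyond the scatter of two such steps. Two cores show only that the size of the step can vary with the core; they do not show which part of the core matters, as the two cores differ in more than one place.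

The compounds shown leave open how a bromomethyl or an aminomethyl group would read in this assay on either core. They also leave open whether a carboxylic acid in place of the ester or amide would alter the step.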